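The compounds below may be only part of what the source reports. "The series", "measured", "known", "first", "only" and "open" are said of these compounds alone.

Of the compounds shown here, three built on one shared core have been tested in an ADME assay on HepG2 cells (Homo sapiens) for cytotoxicity, read by MTT assay, with a stated time of 72 h; a higher number here means that more compound is tolerated, a lower number that less compound is tolerated. Compound 1 `Clc1ccc(/C=N/c2sc3c(c2-c2nc4ccccc4s2)CCCC3)cc1` gives 397 ug/mL. Compound 2 `Clc1ccc(/C=N/c2sc3c(c2-c2nc4ccccc4s2)CCCC3)c(Cl)c1`, which has chloro in place of hydrogen on an aromatic carbon, gives 384 ug/mL. Compound 3 `Fc1ccccc1/C=N/c1sc2c(c1-c1nc3ccccc3s1)CCCC2` gives 398 ug/mL. The steps of a 1.0-fold lower number from compound 1 to compound 2 (0.01 log units; within the scatter), a 1.0-fold higher number from compound 1 to compound 3 (0.00 log units; within the scatter) and a 1.0-fold higher number from compound 2 to compound 3 (0.02 log units; within the scatter) all sit within the scatter, so compound 3 cannot be told apart from compound 1 or compound 2 on these numbers, even though its figure is nominally the top one of the three. Compound 4 `Clc1ccccc1/C=N/c1sc2c(c1-c1nc3ccccc3s1)CCCC2` differs from compound 3 by chloro in place of fluoro on an aromatic carbon. Going by the values given here, the steps that bear on this exchange of one halogen for another on that ring are a 1.0-fold higher number from compound 1 to compound 3 (0.00 log units; within the scatter) and a 1.0-fold higher number from compound 2 to compound 3 (0.02 log units; within the scatter), and the step of a 1.0-fold lower number from compound 1 to compound 2 (0.01 log units; within the scatter) likewise, each within the scatter. The expected step of a 1.0-fold lower number from compound 3 to compound 4 (0.00 log units; within the scatter) is therefore none beyond the scatter. Compound 4 is estimated to give about 395 ug/mL in this assay, most likely between 290 ug/mL and 520 ug/mL.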

Compound 4, half-maximal cytotoxic concentration: 370 ug/mL
Estimate against measurement, compound 4: 1.1-fold (0.03 log units) above, within the range that was stated.
By their numbers in this assay, from the lowest: compounds 4, 2, 1 and 3 (each within the scatter of the next).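

In this assay, going by these compounds alone, chloro in place of fluoro on this aromatic carbon, ortho to a large group, gives a 1.1-fold lower number from compound 3 to compound 4 (0.03 log units; within the scatter) and is the first direct exchange of one halogen for another at this position. Two further comparisons agree: removing the second chloro of the 2,4-dichlorophenyl group gives a 1.0-fold lower number from compound 2 to compound 4 (0.02 log units; within the scatter) and placing the lone chloro on 2-chlorophenyl instead of 4-chlorophenyl gives a 1.1-fold lower number from compound 1 to compound 4 (0.03 log units; within the scatter) so neither the halogen's identity nor these changes in its number or place can be told apart in this assay. No measured evidence bears on why these numbers stay so close.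

Going by these compounds, only fluoro and chloro appear on this ring, so whether an amine or a carboxylic acid there would move the number beyond the scatter stays open. On these data alone, the shared core is the same throughout, so the effect of changing it also stays open.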